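Nitro for chloro on the dichloroacetanilide core

The source may hold more compounds than are shown below. What is called first, only, known or untested is meant among the compounds shown, and "the series" means these compounds.

Three compounds share one core, differing only in one substituent on the aromatic ring. In a functional assay on A549 cells (Homo sapiens) for antiproliferative activity, read by MTT assay, with a stated time of 72 h (on this read-out lower numbers stand for stronger inhibition and higher numbers for weaker inhibition), compound 1 `O=C(Nc1ccccc1)C(Cl)Cl` gives 130000 nM, compound 2 `O=C(Nc1ccccc1F)C(Cl)Cl` gives 87500 nM, and compound 3 `O=C(Nc1ccccc1Cl)C(Cl)Cl` gives 50200 nM. Compound 3 has the lowest number of the three: it lies beyond the scatter from compound 1 but within the scatter of compound 2. The steps seen so far are a 2.6-fold lower number from compound 1 to compound 3 (0.41 log units; beyond the scatter), a 1.5-fold lower number from compound 1 to compound 2 (0.17 log units; within the scatter) and a 1.7-fold lower number from compound 2 to compound 3 (0.24 log units; within the scatter), so swapping one small substituent for another has moved the number only modestly. Compound 4 `O=C(Nc1ccccc1[N+](=O)[O-])C(Cl)Cl` takes the next step: nitro in place of chloro on an aromatic carbon. For the measured compounds named here, no measured step trades chloro for nitro, so the expectation rests on how little the earlier swaps changed things. A step of a 1.0-fold lower number from compound 3 to compound 4 (0.00 log units; within the scatter) in this assay is expected, that is, no clear change beyond the scatter in either direction. The estimate for compound 4 in this assay is 50000 nM, with a range from 20000 nM to 125000 nM.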

Compound 4, half-maximal inhibitory concentration: 198000 nM
For compound 4 the middle estimate is 4.0-fold (0.60 log units) below the measured one, and the stated range ends below it.
By their numbers in this assay, from the lowest: compounds 3, 2, 1 and 4 (each within the scatter of the next, the first and the last beyond it).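

In this assay, the nitro group shows that this position is not indifferent to what sits on it: the change gives a 3.9-fold higher number from compound 3 to compound 4 (0.60 log units; beyond the scatter), the largest step in the series and the first upward step from the chloro compound. Against fluoro it gives a 2.3-fold higher number from compound 2 to compound 4 (0.35 log units; beyond the scatter), and against hydrogen it gives a 1.5-fold higher number from compound 1 to compound 4 (0.18 log units; within the scatter), so nitro does not extend the lower numbers seen with fluoro and chloro, and its result stays within the scatter of the unsubstituted compound. Nothing measured here bears on why nitro and chloro part ways.

The compounds shown leave open whether this rise belongs to nitro alone or would also appear with an amine or a carboxylic acid on the same carbon. They also leave open how a methyl or methoxy group would compare with chloro there.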